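Swapping a Phenyl Tip for a Hydroxylated Alkyl

A few compounds are considered here, and "the series" means these few. Any claim that something is new, unique, unknown or untested is made for them only; others in the source may bear on it.

Compound 1: `NC(=O)c1ncn(C2O[C@H](CO)[C@@H](O)[C@H]2O)c1C#CCO` gives 0.7 ug/mL in a functional assay on L1210 cells (Mus musculus) for inhibition; a higher number here means a weaker inhibitor, a lower number a stronger inhibitor.
Compound 2: `NC(=O)c1ncn(C2O[C@H](CO)[C@@H](O)[C@H]2O)c1C#Cc1ccccc1` gives 20.6 ug/mL in this assay.

Of the two measured compounds, compound 2 stands higher, the step being a 29-fold higher number from compound 1 to compound 2 (1.47 log units; beyond the scatter). Compound 3 `CC(C)(O)C#Cc1c(C(N)=O)ncn1C1O[C@H](CO)[C@@H](O)[C@H]1O` differs from compound 2 by 1-hydroxy-1-methylethyl in place of phenyl on a triple-bonded carbon. Among the measured compounds shown here, the one measured step that bears on this change went from a hydroxymethyl to a phenyl and raised the number sharply; compound 3 brings back a group carrying a hydroxyl, though not the same one as in compound 1. A step back down beyond the scatter is therefore expected, a 6.9-fold lower number from compound 2 to compound 3 (0.84 log units; beyond the scatter). Compound 3 is estimated at 3 ug/mL, with a range from 0.7 ug/mL to 12 ug/mL.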

Compound 3, half-maximal inhibitory concentration: 4.8 ug/mL
For compound 3 the middle estimate is 1.6-fold (0.20 log units) below the measured one; low and high end bracket the measured number.
By their numbers in this assay, from the lowest: compound 1; then compound 3; then compound 2.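

On the triple-bonded carbon, 1-hydroxy-1-methylethyl in place of phenyl gives a 4.3-fold lower number from compound 2 to compound 3 (0.63 log units; beyond the scatter) in this assay and so wins back part of what phenyl lost. Hydroxymethyl keeps its lead, with a 6.9-fold higher number from compound 1 to compound 3 (0.84 log units; beyond the scatter) on moving to the branched group, so carrying a hydroxyl does not by itself restore the number of compound 1. Nothing available explains either step. On these data alone, whether the hydroxyl matters at all stays open: tert-butyl or aminomethyl on the same carbon would help to separate its contribution from that of the branched carbon framework.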